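The compounds below may be only part of what the source reports. "The series", "measured", "known", "first", "only" and "open" are said of these compounds alone.

Compound 1 `O=C1OC(C(O)CO)C(OCCCCC(CO[N+](=O)[O-])O[N+](=O)[O-])=C1O` and compound 2 `O=C1OC(C(O)CO)C(OCCCOc2no[n+]([O-])c2S(=O)(=O)c2ccccc2)=C1O` share a common core and differ in the chain attached to it. Both have been measured in a physicochemical assay for lipophilicity, using the shake flask method, with a stated time of 4 h, at pH 1.0; a lower number here means a more polar compound, a higher number a more lipophilic compound. In that measurement compound 1 gives 0.78, and compound 2 gives 1.18. Compound 2 thus stands highest of the two numbers in hand, with compound 1 the nearest to it and lower by a gap beyond the usual scatter of repeated measurements. Among the compounds with values here, no pair of measured compounds differs in only one place, so no measured step is available to set the size of the change considered next.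

Compound 3 `O=C1OC(C(O)CO)C(OCCCOc2no[n+]([O-])c2-c2ccccc2)=C1O` has not yet been measured in this assay. It differs from compound 2 in one place: phenyl in place of phenylsulfonyl on an aromatic carbon. Without a measured pair to lean on, the expectation rests on the structural change alone. The expected step of a number 0.92 log units higher from compound 2 to compound 3 (beyond the scatter) is upward in this assay and beyond the scatter. Compound 3 is estimated at 2.1, with a range running from 1.5 to 2.7.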

Compound 3, distribution coefficient: 1.53
Compound 3: the middle estimate sits 0.57 log units above what was measured; low and high end bracket the measured number.
By their numbers in this assay, from the lowest: compound 1; then compound 2; then compound 3.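

Within the data shown here, on the aromatic carbon of the five-membered ring, phenyl in place of phenylsulfonyl gives a number 0.35 log units higher from compound 2 to compound 3 (beyond the scatter) in this assay, the first measured step of a single change in this set, and a modest one. The group that leaves has 9 heavy atoms and 2 hydrogen-bond acceptors, the group that enters has 6 heavy atoms and 0 hydrogen-bond acceptors, and both carry one six-membered aromatic ring of carbon only, so the step belongs to a swap that keeps that ring in place. No measurement at hand tells which part of the swap sets the size of this step.

Going by these compounds, this is one pair on one chain, so it remains open whether the same swap would give a step of similar size on a longer chain between the shared core and the five-membered ring. On these data alone, how an amine, a carboxylic acid or a methyl group on the same aromatic carbon would read in this assay also stays open, as does whether a substituent on the phenyl ring would move the number further.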